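Swapping a Chloropiperidine Amide for an Isopropyl Amide

The source may hold more compounds than are shown below. What is called first, only, known or untested is meant among the compounds shown, and "the series" means these compounds.

Compound 3 `COc1ccc(/C=C/c2cc(OC)cc(OC)c2/C=C/C(=O)N2CCC(Cl)CC2)cc1` carries a 4-chloropiperidin-1-yl group on its carbonyl carbon, and in a functional assay on B16-F10 cells (Mus musculus) for inhibition, read by MTT assay, with a stated time of 48 h (a higher number here means a weaker inhibitor, a lower number a stronger inhibitor), compound 3 gives 4690 nM. Among the three measured compounds it stands second highest: compound 1 `CCCCCCCCNC(=O)/C=C/c1c(/C=C/c2ccc(OC)cc2)cc(OC)cc1OC` gives 8060 nM, and the difference between them is within the scatter, while compound 2 `CCCCNC(=O)/C=C/c1c(/C=C/c2ccc(OC)cc2)cc(OC)cc1OC` gives 2080 nM, which lies beyond the scatter. The step of a 3.9-fold lower number from compound 1 to compound 2 (0.59 log units; beyond the scatter) shows that trimming the alkylamino chain lowered the number, and a 2.3-fold higher number from compound 2 to compound 3 (0.35 log units; beyond the scatter) shows that replacing butylamino with the chloropiperidine raised it again. Compound 4 `COc1ccc(/C=C/c2cc(OC)cc(OC)c2/C=C/C(=O)NC(C)C)cc1` differs from compound 3 as follows: isopropylamino in place of 4-chloropiperidin-1-yl on a carbonyl carbon. This change is the reverse of the move from compound 2 to compound 3, and it brings back an acyclic alkylamino group with a hydrogen-bond donor, as in compound 2. The expectation for compound 4 is therefore a modest step downward, a 1.9-fold lower number from compound 3 to compound 4 (0.27 log units; within the scatter), placing it near compound 2 rather than compound 1. Compound 4 is expected to give 2500 nM, with a plausible range from 1000 nM to 6000 nM.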

Compound 4, half-maximal inhibitory concentration: 4020 nM
Estimate against measurement, compound 4: 1.6-fold (0.21 log units) below; the measured number falls inside the stated range.
By their numbers in this assay, from the lowest: compounds 2, 4, 3 and 1 (each within the scatter of the next, the first and the last beyond it).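

In this assay, putting isopropylamino in place of 4-chloropiperidin-1-yl on a carbonyl carbon removes the ring and the chlorine and brings in the amide hydrogen, yet the result stays within the scatter (a 1.2-fold lower number from compound 3 to compound 4 (0.07 log units; within the scatter)). On the amide-type nitrogen, isopropyl is not separated from butyl (a 1.9-fold higher number from compound 2 to compound 4 (0.29 log units; within the scatter)) or from octyl (a 2.0-fold lower number from compound 1 to compound 4 (0.30 log units; within the scatter)), although butyl and octyl themselves lie beyond the scatter of each other (a 3.9-fold lower number from compound 1 to compound 2 (0.59 log units; beyond the scatter)). No supporting measurement explains these results.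

The compounds shown leave open whether the chlorine or the amide hydrogen matters on its own, which an unsubstituted piperidin-1-yl or a dimethylamino group on the carbonyl carbon would test. Also open, as far as these compounds go, is how a cyclopropyl or 2-hydroxyethyl group on the amide-type nitrogen would compare with isopropyl.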